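Appending a carbamoyl to the hydrazine tail of compound 2

A few compounds are considered here, and "the series" means these few. Any claim that something is new, unique, unknown or untested is made for them only; others in the source may bear on it.

Measured compounds:
compound 1, `COc1cc(NC(C)CCCNC(=O)NCCNC(c2ccccc2)(c2ccccc2)c2ccccc2)c2ncccc2c1`, 40000 nM
compound 2, `COc1cc(NC(C)CCCNC(=O)NN)c2ncccc2c1`, >= 250000 nM
compound 3, `NNC(=O)NC(c1ccccc1)c1ccc(Cl)cc1`, 178000 nM

Of the compounds shown here, three have been tested in a functional assay on MIA PaCa-2 cells (Homo sapiens) for inhibition, read by MTT assay, with a stated time of 4 days; on this read-out lower numbers stand for stronger inhibition and higher numbers for weaker inhibition. Compound 1 gives 40000 nM. Compound 3 gives 178000 nM in this assay. Compound 2 reaches only a limit of this assay, >= 250000 nM, and no number is known for it; this is the limit described by the limit of >= 250000 nM in this assay, at which 1 of the 3 values shown sits. Compound 2 therefore sits at the weak end of the values shown, while compound 1 and compound 3 give numbers.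

Compound 4, `COc1cc(NC(C)CCCNC(=O)NNC(=O)NC(CO)(CO)CO)c2ncccc2c1`, has not yet been measured. It differs from compound 2 in one place: (2-hydroxy-1,1-bis(hydroxymethyl)ethyl)carbamoyl in place of hydrogen on an amine nitrogen. Among the compounds with values here, because compound 2 is known only as a limit >= 250000 nM, the size of the step to compound 4 cannot be anchored on a measured pair, and no comparable step among the measured compounds exists.

The expectation is that the step from compound 2 to compound 4 in this assay is small, an at least 1.2-fold lower number from compound 2 to compound 4 (0.09 log units; that floor lies within the scatter), with no direction favoured beyond the usual scatter. Compound 4 is estimated to give about 200000 nM in this assay, within a range of 60000 nM to 500000 nM.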

Compound 4, half-maximal inhibitory concentration: > 250000 nM
Compound 4 gave a limit, no number; the forecaster's own chance of this, stated with the estimate: 55%; middle value at least 1.2-fold (0.09 log units) from the limit.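

In this assay compound 4 gives > 250000 nM, which is a limit and not a number. Compound 2 gives >= 250000 nM, also a limit, so no step can be read between compound 2 and compound 4. The compounds shown leave open whether the (2-hydroxy-1,1-bis(hydroxymethyl)ethyl)carbamoyl changes the read-out in this assay at all.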